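Anti-Inflammatory Hydrazones: From Dimethylaminophenyl to Pyridinyl

The compounds below may be only part of what the source reports. "The series", "measured", "known", "first", "only" and "open" are said of these compounds alone.

Compound 1 `COc1ccc(/C=N/NC(=O)c2cccnc2Nc2cccc(C(F)(F)F)c2)cc1`: 14%
Compound 2 `CN(C)c1ccc(/C=N/NC(=O)c2cccnc2Nc2cccc(C(F)(F)F)c2)cc1`: 28.2%

Of the compounds shown here, two sharing one core have been tested in a functional assay on the whole organism (strain Wistar) for inhibition, with Rattus norvegicus as the target, read by paw edema, with a stated time of 4 h, at a dose of 10 mg/kg by the intraperitoneal route; on this read-out lower numbers stand for less inhibition and higher numbers for more inhibition at the one dose given (going by the name of the read-out). Compound 1 gives 14% in this assay, and compound 2 gives 28.2%. Among the measured compounds shown here, compound 2 therefore stands highest of the two numbers, its nearest neighbour being compound 1, and the one measured step, a number 14.2 percentage points higher from compound 1 to compound 2 (beyond the scatter), lies beyond the scatter.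

Compound 3 `O=C(N/N=C/c1ccncc1)c1cccnc1Nc1cccc(C(F)(F)F)c1` has not yet been measured. It differs from compound 2 by pyridin-4-yl in place of 4-(dimethylamino)phenyl on a carbon with a double bond to nitrogen. For the measured compounds named here, no measured step covers an exchange of this kind, in which the whole aromatic group at that carbon is replaced rather than only its substituent. Going by the values given here, the single step from compound 1 to compound 2 shows only that a change on that ring can move the number by a modest amount in this assay. Compound 3 is therefore expected to land somewhere between the two measured values, with wide uncertainty. The estimated step is a number 8.2 percentage points lower from compound 2 to compound 3 (within the scatter). The estimate for compound 3 in this assay is 20%, with a range from 5% to 38%.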

Compound 3, a percentage reported as inhibition, in the whole organism at one dose (the size of the read-out at that dose, not a potency): 45.9%
For compound 3 the middle estimate is 25.9 percentage points below the measured one, and the stated range ends below it.
By their numbers in this assay, from the lowest: compound 1; then compound 2; then compound 3.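

This position responds to the identity of the whole ring, not only to the substituent it carries. In this assay, the exchange on the carbon with a double bond to nitrogen gives a number 17.7 percentage points higher from compound 2 to compound 3 (beyond the scatter) and, against the 4-methoxyphenyl group, a number 31.9 percentage points higher from compound 1 to compound 3 (beyond the scatter) as the largest step in this set, which places pyridin-4-yl above both substituted phenyl groups shown. Nothing available explains why this ring gives the higher number.

With only one nitrogen-containing ring shown, it remains open whether pyridin-3-yl or pyridin-2-yl at the same carbon would give a similar number, or whether a plain phenyl ring would already do so. It is also unknown whether these differences would hold at other doses or times, since each number describes the size of the effect at one dose and one time and is not a potency.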